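The source may report more compounds than this note shows. Statements on the series, on what has been measured and on what is new or still open speak of the compounds shown alone.

Compound 1 `O=C1N=C(N2N=C(c3ccccc3)CC2c2ccccc2O)S/C1=C1/C(=O)Nc2ccccc21` carries an unsubstituted fused ring on the shared core; in a functional assay on cells (Cancer cell lines, Homo sapiens) for cytotoxicity, read by sulforhodamine B assay, with a stated time of 48 h (a higher number here means a weaker inhibitor of growth, a lower number a stronger inhibitor of growth), compound 1 gives 1990 nM. Compound 2 `O=C1N=C(N2N=C(c3ccccc3)CC2c2ccccc2O)S/C1=C1/C(=O)Nc2ccc(Br)cc21` differs from it by one change, (bromo in place of hydrogen on an aromatic carbon); in this assay compound 2 gives 210 nM, and the step is a 9.5-fold lower number from compound 1 to compound 2 (0.98 log units; beyond the scatter). Compound 3 `COc1ccc(C2=NN(C3=NC(=O)/C(=C4\C(=O)Nc5ccccc54)S3)C(c3ccc(Cl)cc3)C2)cc1` rests on a core whose difference from the core of compound 1 is not broken down here; in this assay compound 3 gives 100000 nM, the highest number of the three measured compounds. Compound 4 `COc1ccc(C2=NN(C3=NC(=O)/C(=C4\C(=O)Nc5ccc(Br)cc54)S3)C(c3ccc(Cl)cc3)C2)cc1` has not yet been run. It stands to compound 3 as compound 2 stands to compound 1, the same kind of change, (bromo in place of hydrogen on an aromatic carbon), with the place described in the same words for both pairs. The step from compound 3 to compound 4 is expected to be a 3.3-fold lower number from compound 3 to compound 4 (0.52 log units; beyond the scatter), smaller than the one seen before, because compound 3 gives 100000 nM and the change is applied on a different core, so the earlier gain need not carry over in full. Compound 4 is expected at 30000 nM, in the range from 8000 nM to 100000 nM.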

Compound 4, concentration for 50% growth inhibition: 130 nM
Estimate against measurement, compound 4: 230-fold (2.36 log units) above; the measured number lies below the stated range.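

In this assay bromo in place of hydrogen on an aromatic carbon gives a 770-fold lower number from compound 3 to compound 4 (2.89 log units; beyond the scatter) and thus lowers the number on the core of compound 3 as it did on the core of compound 1. The direction of the change carries from one core to the other but its size does not, and the gain on the core of compound 3 is much the larger: the same change on two cores in this assay, a 9.5-fold lower number (0.98 log units; beyond the scatter) from compound 1 to compound 2 and a 770-fold lower number (2.89 log units; beyond the scatter) from compound 3 to compound 4, 81-fold (1.91 log units) apart, beyond the scatter of two such steps. Two pairs fix no rule for other cores in the series, and they do not tell which of the differences between the two cores sets the size of the step.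

On these data alone, whether fluoro, an amine or a carboxylic acid in place of hydrogen on the same aromatic carbon would give steps that differ between the cores in the same way remains open. Also open, as far as these compounds go, is whether the large step on the core of compound 3 would persist with other groups in place of the methoxy or the chloro.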